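The compounds below may be only part of what the source reports. "The series", "measured", "known", "first", "only" and "open" are said of these compounds alone.

Compound 2 `CCCCCCN1CC(=O)N(C)[C@@H](Cc2ccc(-c3cc(OC)c(OC)c(OC)c3)cc2)C1=O` stands second highest of the three numbers measured in a functional assay for agonist activity at follicle-stimulating hormone receptor (Homo sapiens), read by a luciferase reporter (a lower number here means that less compound is needed, a higher number that more compound is needed for the effect), where compound 2 gives 3000 nM as its value. Compound 1 `CCCCCCNC(=O)CN1CC(=O)N(C)[C@@H](Cc2ccc(-c3cc(OC)c(OC)c(OC)c3)cc2)C1=O` gives 3 nM in the same this assay and compound 3 `CCCCCN1CC(=O)N(C)[C@@H](Cc2ccc(-c3cc(OC)c(OC)c(OC)c3)cc2)C1=O` gives 9000 nM there. The steps of a 1000-fold higher number from compound 1 to compound 2 (3.00 log units; beyond the scatter) and a 3000-fold higher number from compound 1 to compound 3 (3.48 log units; beyond the scatter) are large, while a 3.0-fold higher number from compound 2 to compound 3 (0.48 log units; beyond the scatter) is modest. Compound 4 `CCCCCCN1C(=O)[C@H](Cc2ccc(-c3cc(OC)c(OC)c(OC)c3)cc2)N(C)C(=O)[C@@H]1C` differs from compound 2 by methyl in place of hydrogen on a saturated ring carbon only. For the measured compounds named here, none of the measured steps touches a ring carbon; all three concern the chain on the ring nitrogen, so none bears directly on this change. A step of no change at the digits printed from compound 2 to compound 4 (within the scatter) is therefore expected, within the scatter and in no firm direction. Compound 4 is estimated to give 3000 nM with a range from 800 nM to 12000 nM in this assay.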

Compound 4, half-maximal effective concentration: 100 nM
For compound 4 the middle estimate is 30-fold (1.48 log units) above the measured one; the measured number lies below the stated range.
By their numbers in this assay, from the lowest: compound 1; then compound 4; then compound 2; then compound 3.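

The saturated ring carbon next to the ring atom that bears a hexyl group proves sensitive to substitution: in this assay, methyl in place of hydrogen gives a 30-fold lower number from compound 2 to compound 4 (1.48 log units; beyond the scatter). This single methyl moves the number further than the change on the chain, a 3.0-fold higher number from compound 2 to compound 3 (0.48 log units; beyond the scatter). No measurement shown accounts for this gain. The compounds shown leave open whether an ethyl or hydroxymethyl group on this carbon would behave like methyl, and what the opposite arrangement of the methyl would give. Going by these compounds, whether the methyl would also lower the number when combined with the hexylcarbamoyl chain of compound 1 remains open too.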